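A few compounds are considered here, and "the series" means these few. Any claim that something is new, unique, unknown or untested is made for them only; others in the source may bear on it.

In a functional assay on PANC-1 cells (Homo sapiens) for cytotoxicity, read by WST assay, with a stated time of 24 h (on this read-out lower numbers stand for stronger inhibition and higher numbers for weaker inhibition), compound 1 (`O=C(CCCCCCCCc1ccc(F)cc1)N1CCCCC1`) gives 99800 nM. Compound 2 (`O=C(CCCCCCCCc1cccc(Cl)c1)N1CCCCC1`) has no number in this read-out, only a limit of > 100000 nM. From the compounds shown here alone, it therefore sits at the limit of > 100000 nM in this assay, at which 1 of the 2 values shown sits, so its true value and its distance from any neighbour remain open.

Compound 3 (`O=C(CCCCCCCCc1ccc(Cl)cc1)N1CCCCC1`) has the same atoms as compound 2, joined differently: 4-chlorophenyl in place of 3-chlorophenyl on a saturated chain carbon, eight bonds along the chain from a carbonyl carbon. This places 4-chlorophenyl in place of 3-chlorophenyl on a saturated chain carbon, eight bonds along the chain from a carbonyl carbon.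

Among the compounds with values here, only one measured step bears on this change, a number no lower from compound 1 to compound 2 (the limit leaves the size open), and its size cannot be read. It replaces 4-fluorophenyl with 3-chlorophenyl, so it is only an indirect guide. The expectation therefore rests mainly on compound 1, which also carries its halogen on a 4-substituted phenyl and gives 99800 nM. No step beyond the scatter is expected, and no clear direction can be assigned, although another limit is quite possible. The expected step is an at least 1.0-fold lower number from compound 2 to compound 3 (0.02 log units; that floor lies within the scatter). For compound 3, the estimated value is 95000 nM, with an expected range from 50000 nM to 180000 nM.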

Compound 3, half-maximal inhibitory concentration: 65500 nM
For compound 3 the middle estimate is 1.5-fold (0.16 log units) above the measured one, within the range that was stated.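

With 4-chlorophenyl in place of 3-chlorophenyl on a saturated chain carbon, eight bonds along the chain from a carbonyl carbon, this assay shows an at least 1.5-fold lower number from compound 2 to compound 3 (0.18 log units; that floor lies within the scatter), so the same atoms joined differently give a readable number in compound 3. Compound 2 remains a limit and not a number, so the full size of this step and of the step from compound 1 to compound 2 cannot be read: the limit of > 100000 nM in this assay, at which 1 of the 3 values shown sits.

Chloro in place of fluoro on an aromatic carbon gives a 1.5-fold lower number from compound 1 to compound 3 (0.18 log units; within the scatter), so compound 1 and compound 3 cannot be told apart in this assay, and the kind of halogen shows no effect beyond the scatter in this pair.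

The compounds shown leave open whether a methoxy or trifluoromethyl group in place of the halogen on the phenyl ring would move the number beyond the scatter. They also leave open how a shorter or longer chain would read in this assay, and whether an amine or a carboxylic acid on the chain would change the result.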